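Two cores, one chain change, three limits only

The source may hold more compounds than are shown below. What is called first, only, known or untested is meant among the compounds shown, and "the series" means these compounds.

Three compounds were measured in a functional assay on MCF7 cells (Homo sapiens) for antiproliferative activity, read by MTT assay; on this read-out lower numbers stand for stronger inhibition and higher numbers for weaker inhibition.

Compound 1 `CCCCCCCCCCCCCCCc1cc(=O)c2c(O)c(C)c(OCOC)cc2o1`: > 67200 nM
Compound 2 `CCCCC/C=C\C/C=C\CCCCCCCC1(O)CC(=O)c2c(O)cc(OCOC)cc2O1`: > 84100 nM
Compound 3 `CCCCC/C=C\C/C=C\CCCCCCCc1cc(=O)c2c(O)c(C)c(OCOC)cc2o1`: > 67200 nM

Each of these values is a limit of this assay, not a number. For compound 1 the value > 67200 nM marks the limit (the limit of > 67200 nM in this assay, at which 2 of the 3 values shown sit). For compound 3 the value > 67200 nM marks that same limit. For compound 2 the value > 84100 nM marks a different limit, (the limit of > 84100 nM in this assay, at which 1 of the 3 values shown sits).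

Compound 1 differs from compound 3 by octyl in place of deca-1,4-dien-1-yl on a saturated chain carbon, seven bonds along the chain from an aromatic carbon, and the step that the two limits leave unreadable from compound 3 to compound 1 cannot be read, since both ends of it sit at a limit.

Compound 4 `CCCCCCCCCCCCCCCC1(O)CC(=O)c2c(O)cc(OCOC)cc2O1` has not been measured. It differs from compound 2 by octyl in place of deca-1,4-dien-1-yl on a saturated chain carbon, seven bonds along the chain from a saturated ring carbon. The cores of compound 2 and compound 3 differ in a way that is not broken down here. The change from compound 2 to compound 4 is the same kind of change as that from compound 3 to compound 1, but the place is not identical: in one case the chain carbon lies seven bonds along the chain from an aromatic carbon, in the other seven bonds along the chain from a saturated ring carbon.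

Compound 2 reached only a limit, > 84100 nM, in this assay. Compound 4 is therefore expected to give 100000 nM, most likely again as a limit rather than a number. The expected range for compound 4 runs from 30000 nM to 300000 nM. The step from compound 2 to compound 4 is expected to be a step that the limit leaves unreadable from compound 2 to compound 4, which rests on the unreadable measured step that the two limits leave unreadable from compound 3 to compound 1 and on compound 2 sitting at the limit of > 84100 nM in this assay, at which 1 of the 3 values shown sits.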

Compound 4, half-maximal inhibitory concentration: > 67200 nM
Compound 4: no number, only a limit; the forecaster's own chance of this, stated with the estimate: 85%; the middle value does not contradict the limit.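

In this assay compound 4 gives > 67200 nM, which is a limit of the assay and not a number. Compound 2 likewise stands at a limit, > 84100 nM. The step between compound 2 and compound 4 therefore cannot be read. The compounds shown leave open how the octyl and deca-1,4-dien-1-yl chains, or the two cores, compare in this assay, as all four values are limits.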